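Methylating the phenol of a urea-linked pyrazole: an estimate

A few compounds are considered here, and "the series" means these few. Any claim that something is new, unique, unknown or untested is made for them only; others in the source may bear on it.

Compound 1 `O=C(Nc1cccc(-n2cc(-c3ccncc3)c(-c3cc(O)cc(Cl)c3)n2)c1)Nc1ccc(Cl)c(C(F)(F)F)c1` stands at the lower of the two numbers in a functional assay on SK-MEL-2 cells (Homo sapiens) for inhibition, read by sulforhodamine B assay, with a stated time of 48 h, tested at 0.1 uM (on this read-out higher numbers stand for a weaker effect at the one concentration tested and lower numbers for a stronger effect), giving 94%; compound 2 `O=C(Nc1cccc(-n2cc(-c3ccncc3)c(-c3cc(O)cc(Cl)c3)n2)c1)Nc1ccc(Cl)c(Cl)c1` gives 96%, and a number 2 percentage points higher from compound 1 to compound 2 (within the scatter). Compound 3 `COc1cc(Cl)cc(-c2nn(-c3cccc(NC(=O)Nc4ccc(Cl)c(C(F)(F)F)c4)c3)cc2-c2ccncc2)c1` differs from compound 1 by methyl in place of hydrogen on an oxygen on an aromatic ring. Among the measured compounds shown here, no measured step touches that oxygen; the only step known, on the far aryl, was small. The methyl is therefore expected to leave the read-out nearly unchanged, a number 2 percentage points higher from compound 1 to compound 3 (within the scatter), with compound 3 estimated at 96% in this assay, within 86% to 105%.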

Compound 3, a percentage reported as activity, at one concentration (the size of the read-out at that concentration, not a potency): 52%
For compound 3 the middle estimate is 44 percentage points above the measured one; measured number outside the range, below it.
By their numbers in this assay, from the lowest: compound 3; then compounds 1 and 2 (each within the scatter of the next).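

Going from hydroxy to methoxy on this aromatic ring moves the read-out in this assay by a large amount (a number 42 percentage points lower from compound 1 to compound 3 (beyond the scatter)), and the lower number marks a stronger effect at the one concentration tested. Among the compounds shown here, the only earlier step, on the far aryl (a number 2 percentage points higher from compound 1 to compound 2 (within the scatter)), gave no sign that the read-out could shift this much, whereas this oxygen clearly matters. Nothing available here accounts for the size of this step.

As far as these compounds go, it remains open whether ethoxy, a longer chain on the oxygen, or an amine in place of the hydroxy would shift the read-out as methoxy does. From the compounds shown here alone, whether methoxy has the same effect alongside chloro on the far aryl also remains open.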